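The source may hold more compounds than are shown below. What is called first, only, known or untested is meant among the compounds shown, and "the series" means these compounds.

Compound 1 `NCCCNc1c(C(=O)NCc2ccc(F)cc2)nc(Br)c2cccnc12`: "not determined" (no result reported)
Compound 2 `CN(C)CCCNc1c(C(=O)NCc2ccc(F)cc2)nc(Br)c2cccnc12`: 1000 nM
Compound 3 `N[C@H]1CC[C@H](Nc2c(C(=O)NCc3ccc(Cl)cc3Cl)nc(Br)c3cccnc23)CC1`: 6000 nM

In a functional assay on SK-BR-3 cells (Homo sapiens) for cytotoxicity, read by MTT assay, with a stated time of 72 h (a lower number here means a stronger inhibitor, a higher number a weaker inhibitor), compound 2 gives 1000 nM, while compound 3 gives 6000 nM. That is the higher of the two numbers, and the gap lies beyond the usual scatter. Compound 1 has no reported result. Compound 4 `N[C@H]1CC[C@H](Nc2c(C(=O)NC3CCCCC3)nc(Br)c3cccnc23)CC1` has not yet been measured and differs from compound 3 in one place: cyclohexyl in place of 2,4-dichlorobenzyl on an amide-type nitrogen. For the measured compounds named here, no measured pair shows this change, so the expectation in this assay is loose: a small rise in the number, not clearly beyond the scatter, with the estimated step of a 1.5-fold higher number from compound 3 to compound 4 (0.18 log units; within the scatter). For compound 4 the estimate is 9000 nM, with an expected range from 3000 nM to 30000 nM.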

Compound 4, half-maximal inhibitory concentration: 4200 nM
Compound 4: the middle estimate sits 2.1-fold (0.33 log units) above what was measured; the range from low to high includes it.
By their numbers in this assay, from the lowest: compound 2; then compounds 4 and 3 (each within the scatter of the next).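

In this assay, for the compounds shown here, the step of a 1.4-fold lower number from compound 3 to compound 4 (0.15 log units; within the scatter) is the first single-place change that can be read. At this amide-type nitrogen, the aromatic ring and both chlorine atoms of 2,4-dichlorobenzyl can give way to cyclohexyl with no difference beyond the scatter. Nothing measured here offers an explanation for this result. Still open, going by these compounds, is whether an unsubstituted benzyl or a cyclopentyl on this nitrogen would read the same. On these data alone, it is also open whether a carboxylic acid or a longer chain there would shift the number beyond the scatter.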